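A few compounds are considered here, and "the series" means these few. Any claim that something is new, unique, unknown or untested is made for them only; others in the source may bear on it.

Going by the values given here, in a physicochemical assay for lipophilicity, measured as octanol-water partition, at pH 7.4 (a higher number here means a more lipophilic compound, a lower number a more polar compound), compound 2 `Cc1ccc2[nH]c(C(=O)N[C@H]3CN(S(=O)(=O)c4ccccc4)C[C@@H]3C(=O)N[C@@H]3CCCN(C)C3)cc2c1` gives 2.7, the higher of the two numbers so far, while compound 1 `Cc1ccc2[nH]c(C(=O)N[C@H]3CN(S(=O)(=O)c4ccccc4)C[C@@H]3C(=O)NC[C@H]3CCCN3)cc2c1` gives 1. Compound 3 `Cc1ccc2[nH]c(C(=O)N[C@H]3CN(S(=O)(=O)c4ccccc4)C[C@@H]3C(=O)N[C@H]3CCCN(C)C3)cc2c1` is still unmeasured, and it differs from compound 2 in this way: the two compounds have the same atoms and bonds and differ only in configuration as drawn: 1 of 3 stereo elements differ; a stereocentre at a saturated ring carbon is drawn R in compound 2 and S in compound 3. Among the compounds with values here, the only measured step, a number 1.70 log units higher from compound 1 to compound 2 (beyond the scatter), was large, but it replaced one group with another, so it gives no direct guide to a change of configuration alone. Within the data shown here, with no measured example of such a change, no step beyond the scatter is expected in this assay, in either direction. The expected step is no change at the digits printed from compound 2 to compound 3 (within the scatter). The estimated value for compound 3 is 2.7, with an expected range of 2.3 to 3.1.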

Compound 3, distribution coefficient: 2.7
Compound 3: the middle estimate sits on the measured number at the digits printed; low and high end bracket the measured number.
By their numbers in this assay, from the lowest: compound 1; then compounds 2 and 3 (each within the scatter of the next).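

In this assay the step on inverting the stereocentre at the saturated ring carbon is no change at the digits printed from compound 2 to compound 3 (within the scatter) and so, at this position, either drawn configuration reads alike. The replacement of (pyrrolidin-2-yl)methyl by 1-methylpiperidin-3-yl also holds for both configurations, with a number 1.70 log units higher from compound 1 to compound 3 (beyond the scatter) matching the earlier step. Going by these compounds alone, this pair is the first to isolate configuration alone, and its reading rests on one fact: the fact that compounds 2 and 3 differ only in the configuration as drawn.

From the compounds shown here alone, whether the same holds for the other two stereocentres stays open. So does the case where the piperidine nitrogen carries an ethyl group or a hydrogen in place of methyl.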